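This account rests on a few compounds, and the source may have more. Where it says the series, first, only, none or still open, it means among the compounds named here.

Of the compounds shown here, three sharing one core have been tested in a functional assay on MDA-MB-435 cells (Homo sapiens) for cytotoxicity, read by MTT assay, with a stated time of 72 h; a lower number here means a stronger inhibitor, a higher number a weaker inhibitor. Compound 1 `NCCNc1c(C(=O)NCc2ccc(F)cc2)nc(Br)c2cccnc12` gives 12000 nM, compound 2 `COC(=O)CNc1c(C(=O)NCc2ccc(F)cc2)nc(Br)c2cccnc12` gives 10000 nM, and compound 3 `O=C(NCc1ccc(F)cc1)c1nc(Br)c2cccnc2c1N1CCNCC1` gives 8000 nM. Compound 3 shows the smallest of the three numbers, but both steps to it lie within the scatter: a 1.5-fold lower number from compound 1 to compound 3 (0.18 log units; within the scatter) and a 1.3-fold lower number from compound 2 to compound 3 (0.10 log units; within the scatter). Compound 4 `CN(C)CCCNc1c(C(=O)NCc2ccc(F)cc2)nc(Br)c2cccnc12` changes compound 3 at one place: (3-(dimethylamino)propyl)amino in place of piperazin-1-yl on an aromatic carbon. The step from compound 1 to compound 3 bears on this change, as it exchanged an (2-aminoethyl)amino chain for the piperazin-1-yl ring on the same aromatic carbon, and it stayed within the scatter, a 1.5-fold lower number from compound 1 to compound 3 (0.18 log units; within the scatter). The expected step for compound 4 is therefore small, a 1.3-fold higher number from compound 3 to compound 4 (0.10 log units; within the scatter). Compound 4 is estimated at 10000 nM, with a range from 4500 nM to 22000 nM.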

Compound 4, half-maximal inhibitory concentration: 7000 nM
Estimate against measurement, compound 4: 1.4-fold (0.15 log units) above; measured number inside the range.
By their numbers in this assay, from the lowest: compounds 4, 3, 2 and 1 (each within the scatter of the next).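

In this assay, an open (3-(dimethylamino)propyl)amino chain on this aromatic carbon in place of the piperazin-1-yl ring changes little (a 1.1-fold lower number from compound 3 to compound 4 (0.06 log units; within the scatter)). The other two new steps also stay within the scatter (a 1.4-fold lower number from compound 2 to compound 4 (0.15 log units; within the scatter); a 1.7-fold lower number from compound 1 to compound 4 (0.23 log units; within the scatter)), so across these four compounds neither the ring nor the longer chain with its dimethylamino end separates from the rest. No available evidence explains this result. Still open, from the compounds shown here alone, is whether a carboxylic acid or a simple unbranched alkyl chain on this carbon would move the number beyond the scatter.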